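Fluoro for chloro: from compound 2 to compound 4

This account rests on a few compounds, and the source may have more. Where it says the series, first, only, none or still open, it means among the compounds named here.

Measured in a functional assay on the whole organism (strain Swiss) with Mus musculus as the target, in the maximal electroshock model, with a stated time of 0.25 h, at a dose of 300 mg/kg by the intraperitoneal route; a higher number here means a stronger effect of the compound at the dose given, a lower number a weaker effect:
Compound 1 `CCC(C(=O)N1CCOCC1)N1C(=O)CCC1=O`: 0%
Compound 2 `CCC(C(=O)N1CCN(c2ccc(Cl)cc2)CC1)N1C(=O)CCC1=O`: 0%
Compound 3 `CC(C(=O)N1CCN(c2ccc(Cl)cc2)CC1)N1C(=O)CCC1=O`: 100%

Compound 2 stands level with compound 1 at the digits shown; together they are the lowest of the three numbers. Its furthest neighbour is compound 3, reached by a number 100 percentage points higher from compound 2 to compound 3 (beyond the scatter), the change there being hydrogen in place of methyl on a saturated chain carbon, two bonds along the chain from an amide-type nitrogen in a ring and a carbonyl carbon.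

Compound 4 `CCC(C(=O)N1CCN(c2ccc(F)cc2)CC1)N1C(=O)CCC1=O` differs from compound 2 by fluoro in place of chloro on an aromatic carbon. Among the measured compounds shown here, no measured pair differs in this way. For the measured compounds named here, the single measured step, from compound 2 to compound 3, alters the chain and leaves the 4-chlorophenyl group untouched, so it says nothing about an exchange on the aromatic carbon. Going by the values given here, nothing among the measured compounds therefore speaks for a step beyond the scatter in this assay in either direction; since compound 2 sits at the floor of the read-out, any departure could only be upward. The expected step is a number 10 percentage points higher from compound 2 to compound 4 (within the scatter). The estimate for compound 4 is 10%, with a range from 0% to 45%.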

Compound 4, a percentage reported as activity, at one dose (the size of the read-out at that dose, not a potency): 0%
Compound 4: middle estimate off by 10 percentage points, on the high side; the measured number falls inside the stated range.
By their numbers in this assay, from the lowest: compounds 1, 2 and 4 (each within the scatter of the next); then compound 3.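

In this assay, among the compounds shown here, the exchange of chloro for fluoro on the aromatic carbon gives no change at the digits printed from compound 2 to compound 4 (within the scatter) and is the only reading of a change at this place, para to a large group. With the chain of compound 2, the lack of effect is therefore not specific to the 4-chlorophenyl group, although both numbers lie at the bottom of the read-out, so this pair cannot show whether the exchange would matter in a compound with an effect to lose. No supporting data bear on this result.

As far as these compounds go, the step of a number 100 percentage points higher from compound 2 to compound 3 (beyond the scatter) rests on the 4-chlorophenyl group alone, and it remains open whether 4-fluorophenyl, with hydrogen in place of methyl on that chain carbon, would match the read-out of compound 3. Also open, from the compounds shown here alone, is how a methoxy group, a trifluoromethyl group or an unsubstituted phenyl ring would read at this place on either chain.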